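The compounds below may be only part of what the source reports. "The series", "measured", "known", "first", "only" and "open" are said of these compounds alone.

Compound 1 `COC(=O)C#CC(CC(C)C)O/C=C/C(=O)OC`: 330 nM
Compound 2 `COC(=O)C#CC(C[C@@H](C)CCC=C(C)C)O/C=C/C(=O)OC`: 3100 nM
Compound 3 `Cc1ccc(S(=O)(=O)C#CC(O/C=C/S(=O)(=O)c2ccc(C)cc2)C(C)C)cc1`: 3800 nM

In a functional assay on HBL-100 cells (Homo sapiens) for antiproliferative activity, read by sulforhodamine B assay, with a stated time of 48 h (a lower number here means a stronger inhibitor of growth, a higher number a weaker inhibitor of growth), compound 1 gives 330 nM, the lowest of the three numbers. Its nearest neighbour is compound 2, while compound 3 stands furthest away; both gaps lie beyond the scatter, so compound 1 is the strongest growth inhibitor of the three measured here.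

Compound 4 `COC(=O)C#CC(O/C=C/C(=O)OC)C1CCCCC1` has not yet been measured. It differs from compound 1 in one place: cyclohexyl in place of isobutyl on a saturated chain carbon bound to an oxygen on an unsaturated carbon and a triple-bonded carbon.

Within the data shown here, only one measured step bears on the same region of the shared core. Going from compound 1 to compound 2 there was a 9.4-fold higher number from compound 1 to compound 2 (0.97 log units; beyond the scatter), a loss of potency when more carbon was added to the saturated chain carbon that sits on the oxygen on an unsaturated carbon and the triple-bonded carbon. Compound 3 belongs to a different pair of end groups and offers no direct comparison. The change to compound 4 also enlarges that substituent, though by fewer heavy atoms and with a ring, so a smaller step in the same direction is expected, a 2.7-fold higher number from compound 1 to compound 4 (0.44 log units; beyond the scatter). Compound 4 is therefore estimated to give 900 nM in this assay, with a range from 300 nM to 3000 nM.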

Compound 4, concentration for 50% growth inhibition: 2500 nM
For compound 4 the middle estimate is 2.8-fold (0.44 log units) below the measured one; the measured number falls inside the stated range.
By their numbers in this assay, from the lowest: compound 1; then compounds 4, 2 and 3 (each within the scatter of the next).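

In this assay, cyclohexyl in place of isobutyl on this saturated chain carbon gives a 7.6-fold higher number from compound 1 to compound 4 (0.88 log units; beyond the scatter), which shows that the loss seen with the longer open chain of compound 2 also occurs with a six-membered ring of carbon only. The two enlarged groups end up level: compound 4 at 2500 nM and compound 2 at 3100 nM lie within the scatter of each other, so among these three compounds only isobutyl keeps the number low, even though the cyclohexyl and the chain of compound 2 differ in shape. No measurement available here accounts for this loss of growth inhibition.

On these data alone, what remains open is whether isobutyl is close to the best group at this place or simply the smallest of the three compared with these methyl ester end groups. A shorter chain such as ethyl, a phenyl ring, or a cyclohexyl carrying an amine or a carboxylic acid could each move the number in either direction, and the compounds shown give no way of telling which.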